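Swapping the aryl group on a shared core

A few compounds are considered here, and "the series" means these few. Any claim that something is new, unique, unknown or untested is made for them only; others in the source may bear on it.

Compound 2 `CC(=O)N1N=C(c2ccccc2C)OC1c1ccc(Cl)c(Cl)c1` carries a 2-methylphenyl group on a carbon with a double bond to nitrogen of the shared core. For the measured compounds named here, in an assay on BTI cells for inhibition of Amine oxidase [flavin-containing] B (Homo sapiens), read by fluorescence and Amplex Red, with a stated time of 15 min (a higher number here means a weaker inhibitor, a lower number a stronger inhibitor), compound 2 gives 2460 nM, the lowest of the two numbers known so far. Going by the values given here, its nearest neighbour is compound 1 `CC(=O)N1N=C(c2ccncc2)OC1c1ccc(Cl)c(Cl)c1`, which in this assay gives 69400 nM; the only measured step, a 28-fold lower number from compound 1 to compound 2 (1.45 log units; beyond the scatter), shows how much the group at this place can matter. Compound 3 `CC(=O)N1N=C(c2ccc(Cl)cc2)OC1c1ccc(Cl)c(Cl)c1` differs from compound 2 by 4-chlorophenyl in place of 2-methylphenyl on a carbon with a double bond to nitrogen. Among the compounds with values here, this exchanges one six-membered aromatic ring of carbon only for another at the same place, a smaller change than the one between compound 1 and compound 2, so a step in this assay well inside the size of that one, in either direction, is expected, with a slight lean toward a lower number. For compound 3 the expected result in this assay is 1500 nM, within 300 nM to 8000 nM, which means an expected step of a 1.6-fold lower number from compound 2 to compound 3 (0.21 log units; within the scatter).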

Compound 3, half-maximal inhibitory concentration: 627 nM
Beside the measured number, compound 3's estimate is 2.4-fold (0.38 log units) above it; the measured number falls inside the stated range.
By their numbers in this assay, from the lowest: compound 3; then compound 2; then compound 1.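

Even with one six-membered aromatic ring of carbon only replaced by another, the group at this place still moves the number: the exchange of 2-methylphenyl for 4-chlorophenyl gives a 3.9-fold lower number from compound 2 to compound 3 (0.59 log units; beyond the scatter) in this assay. The range at this place is also wider than the earlier step showed, with 4-chlorophenyl in place of pyridin-4-yl giving a 110-fold lower number from compound 1 to compound 3 (2.04 log units; beyond the scatter), and compound 3 is now the strongest inhibitor of the three. Nothing measured here accounts for either step.

The compounds shown leave open whether the gain follows the swap of methyl for chlorine or the shift from the 2 to the 4 in the group's name, which 4-methylphenyl and 2-chlorophenyl at this place would help to separate. Also open, as far as these compounds go, is how a phenyl ring carrying an amine or a carboxylic acid would read here.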